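Carboxymethyl to 1-carboxyethyl on compound 1

The source may report more compounds than this note shows. Statements on the series, on what has been measured and on what is new or still open speak of the compounds shown alone.

Among the compounds with values here, only two compounds have numbers so far in an ADME assay on Caco-2 cells (Homo sapiens) for permeability, read by HPLC, in the apical to basolateral direction, with a stated time of 60 min, at pH 6.5, tested at 10 uM; a higher number here means that the compound crosses the layer faster, a lower number that the compound crosses the layer more slowly. Compound 1 `O=C(O)Cn1nc(Cn2cc3cc(OCC4CC4)c(Cl)cc3n2)c2ccccc2c1=O` gives 0.3 10^-6 cm/s, the lower of the two numbers. Compound 2 `O=C(O)Cc1nn(Cc2cn3cc(OCC4CC4)c(Cl)cc3n2)c2ccccc2c1=O` gives 0.8 10^-6 cm/s, a gap beyond the usual scatter. These two compounds differ in more than one place, so their gap cannot be assigned to any single change. Within the data shown here, compound 1 therefore stands at the low end of a very short range, and no measured step bears directly on the next change.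

Compound 3 `C[C@H](C(=O)O)n1nc(Cn2cc3cc(OCC4CC4)c(Cl)cc3n2)c2ccccc2c1=O` carries methyl in place of hydrogen on a saturated chain carbon bound to an aromatic nitrogen and a carbonyl carbon. Cut one bond further out, this reads carboxymethyl to 1-carboxyethyl. Among the measured compounds shown here, with no measured precedent, the expectation in this assay is a small upward move that stays within the scatter. The expected size is a 1.5-fold higher number from compound 1 to compound 3 (0.18 log units; within the scatter). For compound 3 the estimated value is 0.45 10^-6 cm/s, with an expected range from 0.2 10^-6 cm/s to 1 10^-6 cm/s.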

Compound 3, apparent permeability: 1 10^-6 cm/s
For compound 3 the middle estimate is 2.2-fold (0.35 log units) below the measured one; measured number inside the range.
By their numbers in this assay, from the lowest: compound 1; then compounds 2 and 3 (each within the scatter of the next).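

Within the data shown here, the saturated chain carbon bound to an aromatic nitrogen and a carbonyl carbon now has the first measured step: in this assay, methyl in place of hydrogen gives a 3.3-fold higher number from compound 1 to compound 3 (0.52 log units; beyond the scatter) on the core of compound 1. This position therefore responds to the change from carboxymethyl to 1-carboxyethyl, and a single added carbon is enough to carry the number beyond the scatter, although the step remains modest in size. Nothing available accounts for the step, and no measurement of any property of the group bears on it.

Going by these compounds, whether ethyl or a second methyl on this carbon would extend the step, and whether the mirror-image arrangement at this carbon would match it, remains open. Also open, on these data alone, is whether the step depends on the carboxylic acid, which an amide or a tetrazole in its place would test, and whether the same methyl would have a comparable effect on the core of compound 2.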